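The compounds below may be only part of what the source reports. "The series", "measured", "known", "first", "only" and "open" are said of these compounds alone.

Compound 1 `CCCCCCCCS(=O)(=O)Nc1ccc(-c2cccc(F)c2)cc1C(=O)O` gives 37600 nM in an assay on mitochondria (strain BALB/c) for inhibition of glycerol-3-phosphate acyltransferase 1, mitochondrial (Mus musculus), read by scintillation counting, with a stated time of 10 min; on this read-out higher numbers stand for weaker inhibition and lower numbers for stronger inhibition.
Compound 2 `CCCCCCCCS(=O)(=O)Nc1ccc(C(=O)c2ccc(OC)cc2)cc1C(=O)O` gives 44300 nM in this assay.

Compound 2 holds the highest of the two numbers in this assay; its nearest neighbour is compound 1, and the step of a 1.2-fold higher number from compound 1 to compound 2 (0.07 log units; within the scatter) lies within the scatter. Compound 3 `CCCCCCCCS(=O)(=O)Nc1ccc(/C=C/c2ccc(OC)cc2)cc1C(=O)O` differs from compound 2 by 2-(4-methoxyphenyl)ethenyl in place of (4-methoxyphenyl)carbonyl on an aromatic carbon. Among the compounds with values here, no measured step touches this part of the molecule; the only step available replaces the whole side group and is within the scatter, so it gives little guidance. Compound 3 is therefore expected to move no further than the scatter, a 1.4-fold lower number from compound 2 to compound 3 (0.14 log units; within the scatter). Compound 3 is estimated at 32000 nM, with a range from 10000 nM to 100000 nM.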

Compound 3, half-maximal inhibitory concentration: 37100 nM
Compound 3: middle estimate off by 1.2-fold (0.06 log units), on the low side; low and high end bracket the measured number.
By their numbers in this assay, from the lowest: compounds 3, 1 and 2 (each within the scatter of the next).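

In this assay, 2-(4-methoxyphenyl)ethenyl in place of (4-methoxyphenyl)carbonyl gives a 1.2-fold lower number from compound 2 to compound 3 (0.08 log units; within the scatter), so losing the carbonyl and one hydrogen-bond acceptor at this position does not move the number beyond the scatter. 2-(4-methoxyphenyl)ethenyl in place of 3-fluorophenyl gives a 1.0-fold lower number from compound 1 to compound 3 (0.01 log units; within the scatter), so all three side groups on this carbon stand within the scatter of one another. Nothing available explains this result. Going by these compounds, it remains open whether a small group here, such as an amine or a carboxylic acid, would shift the number beyond the scatter.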